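The source may report more compounds than this note shows. Statements on the series, on what has been measured and on what is new or still open speak of the compounds shown alone.

Compound 1 `O=c1ccoc2cc(OCc3cn(Cc4ccc(Cl)cc4)nn3)ccc12` gives in a functional assay on SGC-7901 cells (Homo sapiens) for cytotoxicity, read by MTT assay, with a stated time of 48 h (a higher number here means a weaker inhibitor, a lower number a stronger inhibitor), only a limit, > 100000 nM.
Compound 2 `O=c1ccoc2cc(OCc3cn(Cc4ccccc4Cl)nn3)ccc12` gives in this assay only a limit, > 100000 nM.

Compound 2 therefore stands at the edge of what this assay can report, not at a number. For the measured compounds named here, the one measured step, a step that the two limits leave unreadable from compound 1 to compound 2, cannot be read for size, because of the limit of > 100000 nM in this assay, at which 2 of the 2 values shown sit. Compound 3 `O=c1ccoc2cc(OCc3cn(Cc4ccccc4F)nn3)ccc12` differs from compound 2 by fluoro in place of chloro on an aromatic carbon. Going by the values given here, no measured step bears on this change, so no direction beyond the scatter can be expected for compound 3 in this assay. The expectation for compound 3 is 150000 nM, within 50000 nM to 450000 nM, which is an expected step that the limit leaves unreadable from compound 2 to compound 3.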

Compound 3, half-maximal inhibitory concentration: > 100000 nM
Compound 3 ended at the assay's limit; the forecaster's own chance of this, stated with the estimate: 85%; the middle value does not contradict the limit.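

No step among compound 1, compound 2 and compound 3 can be read for size, because all three sit at a limit in this assay: the limit of > 100000 nM in this assay, at which 3 of the 3 values shown sit.

How strongly any of these compounds acts on these cells remains open, as does any effect of the halogen change.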